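Replacing a chain hydroxyl with a pyrrolidinone on compound 2

The source may report more compounds than this note shows. Statements on the series, on what has been measured and on what is new or still open speak of the compounds shown alone.

Compound 1 `OCCNc1cc2c(NCCO)ncnc2cn1` and compound 2 `OCCOc1cc2c(NC3CCCCC3)ncnc2cn1` share a core and were tested in a functional assay on CHO cells for antagonist activity at metabotropic glutamate receptor 1 (Rattus norvegicus), with a stated time of 5 min; a higher number here means a weaker inhibitor, a lower number a stronger inhibitor. In this assay compound 1 gives 6150 nM, whereas compound 2 gives 177 nM, the lower of the two numbers and well beyond the scatter apart. Compound 3 `O=C1CCCN1CCOc1cc2c(NC3CCCCC3)ncnc2cn1` has not yet been measured; it differs from compound 2 by 2-oxopyrrolidin-1-yl in place of hydroxy on a saturated chain carbon, two bonds along the chain from an oxygen on an aromatic ring. Among the compounds with values here, with no comparable step among the measured pair, the step of a 1.7-fold higher number from compound 2 to compound 3 (0.23 log units; within the scatter) is expected to be small, not clearly beyond the scatter. Compound 3 is therefore estimated at 300 nM, within a range from 80 nM to 1200 nM.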

Compound 3, inhibition constant: 20 nM
The estimate for compound 3 lay 15-fold (1.18 log units) above the measured number; the whole stated range lies above it.
By their numbers in this assay, from the lowest: compound 3; then compound 2; then compound 1.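

In this assay, the saturated chain carbon two bonds along the chain from the oxygen on the aromatic ring accepts a much larger group than hydroxy: 2-oxopyrrolidin-1-yl gives an 8.9-fold lower number from compound 2 to compound 3 (0.95 log units; beyond the scatter). The hydrogen-bond donor of the hydroxy group is therefore not needed for a low number in this pair. Nothing measured here explains the step. From the compounds shown here alone, whether the carbonyl or the five-membered ring matters more remains open. So does whether an open-chain amide, a pyrrolidine amine or a longer chain to 2-oxopyrrolidin-1-yl would behave alike.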